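The source may report more compounds than this note shows. Statements on the series, on what has been measured and on what is new or still open speak of the compounds shown alone.

Measured so far in the series:

compound 1, `O=C(CN1CCCC1)OC1CC2(N3CCCCC3)CC(c3ccccc3)C1C(c1ccccc1)C2`: 16400 nM
compound 2, `CN1CCN(CC(=O)OC2CC3(N(C)C)CC(c4ccccc4)C2C(c2ccccc2)C3)CC1`: 39900 nM

In an ADME assay on L6 cells (Rattus norvegicus) for cytotoxicity, read by resazurin assay, with a stated time of 72 h (on this read-out lower numbers stand for stronger inhibition and higher numbers for weaker inhibition), compound 2 gives 39900 nM, the highest of the two numbers at hand. The nearest value is that of compound 1, which in this assay gives 16400 nM, a lower number and beyond the usual scatter, so compound 2 stands as the weaker inhibitor of the two. Within the data shown here, no pair of measured compounds differs in a single place, so no measured step is available to guide the next change.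

Compound 3, `CN(C)C12CC(N)C(C(c3ccccc3)C1)C(c1ccccc1)C2`, is not yet measured. Relative to compound 2 the change is amino in place of (((4-methylpiperazin-1-yl)methyl)carbonyl)oxy on a saturated ring carbon. Both measured compounds carry an ester side chain on the same ring carbon, and nothing in the data shows how the core behaves without it. The step is expected to be small to moderate, with a higher number somewhat more likely than a lower one, and may well stay within the scatter: a 1.5-fold higher number from compound 2 to compound 3 (0.18 log units; within the scatter). For compound 3 in this assay the expected value is 60000 nM, with a range of 20000 nM to 180000 nM.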

Compound 3, half-maximal inhibitory concentration: 40900 nM
Compound 3: the middle estimate sits 1.5-fold (0.17 log units) above what was measured; the measured number falls inside the stated range.
By their numbers in this assay, from the lowest: compound 1; then compounds 2 and 3 (each within the scatter of the next).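

In this assay, amino in place of (((4-methylpiperazin-1-yl)methyl)carbonyl)oxy on this saturated ring carbon gives a 1.0-fold higher number from compound 2 to compound 3 (0.01 log units; within the scatter), so compounds 2 and 3 cannot be told apart in this read-out. Among these compounds, this is the first view of the core without an ester side chain at this position, and it shows that for the core of compound 2, the read-out does not depend on that side chain: a group of 11 heavy atoms, including a six-membered non-aromatic ring, can give way to a single nitrogen with no difference beyond the scatter. No supporting data explain why the two compounds read alike.

Still open, on these data alone, is whether a hydroxyl group, a carboxylic acid or a longer chain ending in an amine on this ring carbon would also stay within the scatter of compound 3. Also open, as far as these compounds go, is whether amino in place of the ester side chain would read the same way on the core of compound 1, which has a piperidine ring on the ring atom that bears the dimethylamino group in compound 3.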